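From Vinyl to Prop-1-en-1-yl on the Shared Core

The source may report more compounds than this note shows. Statements on the series, on what has been measured and on what is new or still open speak of the compounds shown alone.

Among the measured compounds shown here, in a functional assay on P388 cells (Mus musculus) for cytotoxicity (a higher number here means a weaker inhibitor, a lower number a stronger inhibitor), compound 1 `CCCCCN1C(=O)[C@@H](C)NC(=O)[C@@H]2Cc3ccc(OC)c(c3)Oc3ccc(cc3)C[C@@H](C(=O)N2C)N(C)C(=O)[C@H](C)NC(=O)[C@H](Cc2ccc(OC)cc2)N(C)C(=O)[C@@H]1C` gives 21.4 nM and compound 2 `C=CCN1C(=O)[C@@H](C)NC(=O)[C@@H]2Cc3ccc(OC)c(c3)Oc3ccc(cc3)C[C@@H](C(=O)N2C)N(C)C(=O)[C@H](C)NC(=O)[C@H](Cc2ccc(OC)cc2)N(C)C(=O)[C@@H]1C` gives 18.6 nM as its value, so compound 2 stands level with its only neighbour, within the scatter. Compound 3 `C/C=C/CN1C(=O)[C@@H](C)NC(=O)[C@@H]2Cc3ccc(OC)c(c3)Oc3ccc(cc3)C[C@@H](C(=O)N2C)N(C)C(=O)[C@H](C)NC(=O)[C@H](Cc2ccc(OC)cc2)N(C)C(=O)[C@@H]1C` carries the change prop-1-en-1-yl in place of vinyl on a saturated chain carbon bound to an amide-type nitrogen in a ring and so has prop-1-en-1-yl in place of vinyl on a saturated chain carbon bound to an amide-type nitrogen in a ring. For the measured compounds named here, the one measured step at this place, a 1.2-fold lower number from compound 1 to compound 2 (0.06 log units; within the scatter) and within the scatter, put vinyl in place of butyl, so no step beyond the scatter is expected in this assay for this change. Compound 3 is estimated at 19 nM with an expected range of 9 nM to 40 nM in this measurement. The expected step, a 1.0-fold higher number from compound 2 to compound 3 (0.01 log units; within the scatter) as estimated, stays within the scatter.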

Compound 3, half-maximal inhibitory concentration: 9.12 nM
Beside the measured number, compound 3's estimate is 2.1-fold (0.32 log units) above it; the range from low to high includes it.
By their numbers in this assay, from the lowest: compound 3; then compounds 2 and 1 (each within the scatter of the next).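

In this assay, this position, on a saturated chain carbon bound to an amide-type nitrogen in a ring, now shows a step beyond the scatter: prop-1-en-1-yl in place of vinyl gives a 2.0-fold lower number from compound 2 to compound 3 (0.31 log units; beyond the scatter). Prop-1-en-1-yl in place of butyl gives a 2.3-fold lower number from compound 1 to compound 3 (0.37 log units; beyond the scatter), so the position does respond to the group placed there, though only modestly. Nothing measured here accounts for either step.

Going by these compounds, whether a longer alkenyl chain, a benzyl group or a chain ending in an amine would continue this trend stays open. Also open, on these data alone, is whether the double bond itself matters.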